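The source may hold more compounds than are shown below. What is called first, only, known or untested is meant among the compounds shown, and "the series" means these compounds.

In a functional assay on QG-56 cells (Homo sapiens) for antiproliferative activity (a lower number here means a stronger inhibitor, a higher number a weaker inhibitor), compound 1 (`Cn1cncc1C(O)(c1ccc([N+](=O)[O-])cc1)c1cc2cc([N+](=O)[O-])cc(-c3ccccc3)c2o1`) gives 547 nM, and compound 2 (`Cn1cncc1[C@@](N)(c1ccc(C#N)cc1)c1cc2cc(C#N)cc(-c3cccc(C#N)c3)c2o1`) gives 2 nM. Compound 1 therefore holds the higher, weaker number of the pair, by a margin well beyond the scatter. For the measured compounds named here, no two measured compounds differ in one place only, so the data offer no direct guide to any single change. Compound 3 (`Cn1cncc1C(O)(c1ccc(I)cc1)c1cc2cc([N+](=O)[O-])cc(-c3ccccc3)c2o1`) keeps the core of compound 1 and alters one group: 4-nitrophenyl becomes 4-iodophenyl, with iodo in place of nitro on an aromatic carbon. Going by the values given here, with no such step to go on, the expectation rests on compound 1 alone at 547 nM, and no shift beyond the scatter is expected in either direction. The expected change is small: a 1.4-fold lower number from compound 1 to compound 3 (0.14 log units; within the scatter). Compound 3 is estimated at 400 nM, within a range from 120 nM to 1300 nM.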

Compound 3, half-maximal inhibitory concentration: > 10000 nM
Compound 3 gave a limit, no number; the forecaster's own chance of this, stated with the estimate: 3%; at least 25-fold (1.39 log units) between middle value and limit.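

In this assay, compound 3 gives > 10000 nM, which is a limit of the assay and not a number. Putting iodo in place of nitro on this aromatic carbon, with the rest of compound 1 unchanged, brings an at least 18-fold higher number from compound 1 to compound 3 (1.26 log units; beyond the scatter), so activity in this series is sensitive to the group at this position. How much further the step runs cannot be read from a single limit: the limit of > 10000 nM in this assay, at which 1 of the 3 values shown sits.

Among compounds that differ in one place, only nitro and iodo are shown on this carbon, so it remains open whether nitro is especially favourable here or iodo especially poor. An amine, a methoxy group or a carboxylic acid at the same position would help separate these two readings.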